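This account rests on a few compounds, and the source may have more. Where it says the series, first, only, none or still open, it means among the compounds named here.

The series shares a core in which a pyridin-2-ylamino group sits on the furan ring, varied only at the neighbouring ring nitrogen substituent. Compound 1 `CCCCNc1oc2c(C)ncc(CO)c2c1Nc1ccccn1` carries a butylamino group there and in a functional assay on HEK293 cells for agonist activity at Toll-like receptor 8 (Homo sapiens), read by reporter gene assay (a higher number here means that more compound is needed for the effect, a lower number that less compound is needed), compound 1 gives 9380 nM. Compound 2 `Cc1ncc(CO)c2c(Nc3ccccn3)c(N)oc12` carries a free amino group, and in this assay compound 2 is recorded as "not active" (no number reported). Compound 3 `Cc1ncc(CO)c2c(Nc3ccccn3)c(NC(C)(C)CC(C)(C)C)oc12` carries a 1,1,3,3-tetramethylbutylamino group, and in this assay compound 3 is likewise recorded as "not active" (no number reported). For the measured compounds named here, compound 3 thus stands without a number, as does compound 2, so no step between measured compounds can be given here. Compound 4 `Cc1ncc(CO)c2c(Nc3ccccn3)c(N[C@@H](C)c3ccccc3)oc12` differs from compound 3 in one place: 1-phenylethyl in place of 1,1,3,3-tetramethylbutyl on a nitrogen on an aromatic ring. With no numbered step available, the expectation for compound 4 can only be framed loosely: either it stays without a number like compound 3, or it regains a weak effect in the region that compound 1 shows at 9380 nM. On that basis compound 4 is estimated to give 12000 nM in this assay, with a wide range from 3000 nM to 50000 nM.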

Compound 4, half-maximal effective concentration: 4270 nM
The estimate for compound 4 lay 2.8-fold (0.45 log units) above the measured number; measured number inside the range.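

In this assay compound 3 is recorded as "not active", whereas compound 4 gives 4270 nM and thus has a number, although the 1,1,3,3-tetramethylbutyl and 1-phenylethyl groups each count 8 heavy atoms, all carbon; at this nitrogen, that count alone therefore does not decide whether a number appears. The aromatic ring of 1-phenylethyl is also compatible with a measurable effect, and the change from butyl to 1-phenylethyl gives a 2.2-fold lower number from compound 1 to compound 4 (0.34 log units; beyond the scatter), a modest gain that goes beyond the scatter. Nothing available explains why these groups differ.

The compounds shown leave open whether the opposite stereocentre of 1-phenylethyl would give a similar number. They also leave open how a benzyl group or a longer chain such as pentyl would compare at this nitrogen.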